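This account rests on a few compounds, and the source may have more. Where it says the series, first, only, none or still open, it means among the compounds named here.

Measured so far in a functional assay on A549 cells (Homo sapiens) for antiproliferative activity, read by MTT assay, with a stated time of 72 h; a lower number here means a stronger inhibitor, a higher number a weaker inhibitor:

Compound 1 `COc1cc2ncnc(Nc3ccc(F)c(Cl)c3)c2cc1OCCCCC(=O)Nc1ccc(S(N)(=O)=O)cc1`: 15500 nM
Compound 2 `COc1cc2ncnc(Nc3ccc(C)cc3)c2cc1OCCCCC(=O)Nc1ccc(S(N)(=O)=O)cc1`: > 40000 nM, a limit of the assay, not a number

Compound 2 stands at the edge of what this assay reports: its reading > 40000 nM is a limit, so only a range is known for it. For the measured compounds named here, the single measured step, an at least 2.5-fold higher number from compound 1 to compound 2 (0.41 log units; beyond the scatter), is itself bounded by that limit (the limit of > 40000 nM in this assay, at which 1 of the 2 values shown sits), so only its lower bound is fixed.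

Compound 3 `COc1cc2ncnc(Nc3ccccc3)c2cc1OCCCCC(=O)Nc1ccc(S(N)(=O)=O)cc1` differs from compound 2 by hydrogen in place of methyl on an aromatic carbon, para to a large group. Going by the values given here, no measured pair shows this change. Among the compounds with values here, the one known step, an at least 2.5-fold higher number from compound 1 to compound 2 (0.41 log units; beyond the scatter), exchanges the whole aryl substitution pattern and gives no direct read on removing the methyl alone. With compound 2 already at a limit, the step to compound 3 is expected to be a number no higher from compound 2 to compound 3 (the limit leaves the size open), that is, nothing beyond the scatter in either direction. Compound 3 is estimated at 40000 nM, within 15000 nM to 100000 nM, with a fair chance that this assay again reports only a limit.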

Compound 3, half-maximal inhibitory concentration: > 40000 nM
Compound 3: no number, only a limit (the forecaster's own chance of this, stated with the estimate: 60%); the middle value sits exactly at the limit.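

In this assay compound 3 also gives only a limit, > 40000 nM, so taking the methyl off the 4-methylphenyl group has no size that can be stated, and the step between compound 2 and compound 3 cannot be read. What is new is a second aryl group on the same nitrogen that reads on the weaker side of compound 1, an at least 2.5-fold higher number from compound 1 to compound 3 (0.41 log units; beyond the scatter), with only the lower bound of that step fixed, as for compound 2. Compound 1 is now the only compound with a number, and the series presses against the top of the read-out: the limit of > 40000 nM in this assay, at which 2 of the 3 values shown sit.

The compounds shown do not separate the chloro from the fluoro substituent of the 3-chloro-4-fluorophenyl group, as each readable step exchanges the whole aryl pattern. Also open, going by these compounds, is whether a 3-chlorophenyl or a 4-fluorophenyl group on that nitrogen, a longer chain, or a carboxylic acid in place of the sulfonamide would give readings that can be compared as numbers in this assay.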